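The compounds below may be only part of what the source reports. "The series", "measured", "known", "first", "only" and "open" are said of these compounds alone.

Two members of the series have been run in a functional assay on MDA-MB-231 cells (Homo sapiens) for antiproliferative activity, read by MTT assay, with a stated time of 72 h (on this read-out lower numbers stand for stronger inhibition and higher numbers for weaker inhibition), so far. Compound 1 `COc1cc(NC(=O)c2cccnc2)ccc1-c1noc(-c2cccc(NS(=O)(=O)c3ccc(NC(C)=O)cc3)c2)n1` reaches only the limit of the assay; in this assay compound 1 gives > 10000 nM, which is a limit and not a number. Compound 2 `O=C(Nc1ccc(Cl)cc1)Nc1cccc(-c2nc(-c3ccc(NC(=O)c4cccnc4)cc3Cl)no2)c1` stands at the same point: in this assay compound 2 gives > 10000 nM, again a limit. For the measured compounds named here, the two values shown therefore sit together at the limit of > 10000 nM in this assay, at which 2 of the 2 values shown sit, and no step between measured compounds can be computed.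

Compound 3 `CC(=O)Nc1ccc(NC(=O)Nc2cccc(-c3nc(-c4ccc(NC(=O)c5cccnc5)cc4Cl)no3)c2)cc1` differs from compound 2 in one place, (acetamido in place of chloro on an aromatic carbon), at a carbon of a six-membered aromatic ring of carbon only, para to a large group. With compound 2 at a limit, the step from compound 2 to compound 3 in this assay is expected to be none beyond the scatter, a step that the limit leaves unreadable from compound 2 to compound 3, and most likely another limit. For compound 3 the estimate in this assay is 15000 nM, with a range from 5000 nM to 50000 nM.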

Compound 3, half-maximal inhibitory concentration: > 10000 nM
Compound 3: a limit, no number (the forecaster's own chance of this, stated with the estimate: 75%); the middle value does not contradict the limit.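

No step can be read from compound 2 to compound 3, as both values are limits in this assay and not numbers: the limit of > 10000 nM in this assay, at which 3 of the 3 values shown sit.

The compounds shown leave open what acetamido in place of chloro does to antiproliferative activity, and which structures in the series give a measurable value.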